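Cyclopropyl for propargyl on the amide of compound 2

The compounds below may be only part of what the source reports. "The series", "measured", "known", "first", "only" and "open" are said of these compounds alone.

Three amides built on a shared core have been measured in a toxicity assay on the whole organism (strain Icem-CET (SPF Caw)) for cytotoxicity, with Mus musculus as the target; a lower number here means that less compound is needed, a higher number that more compound is needed for the effect. Compound 1 `COc1ccc(/C(C)=C(/C)C(=O)NC2CC2)cc1` gives 300 mg/kg, compound 3 `C/C(C(=O)NC1CC1)=C(\C)c1ccc(C)cc1` gives 280 mg/kg, and compound 2 `C#CCNC(=O)/C(C)=C(\C)c1ccc(Br)cc1` gives 180 mg/kg. Compound 2 has the smallest number of the three, but its gap to compound 3 and its gap to compound 1 both sit within the usual scatter of repeated measurements, so no real ordering can be read from them. Going by the values given here, the only single-point step among the measured compounds, a 1.1-fold lower number from compound 1 to compound 3 (0.03 log units; within the scatter), changes a group on the aromatic ring and stays within the scatter as well.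

Compound 4 `C/C(C(=O)NC1CC1)=C(/C)c1ccc(Br)cc1` is the next compound to be measured. It differs from compound 2 by cyclopropyl in place of propargyl on an amide-type nitrogen. Among the compounds with values here, no measured step addresses this change directly: compounds 1 and 3 already carry the cyclopropyl group but differ from compound 2 on the aromatic ring too, and their numbers lie within the scatter of compound 2. With nothing pointing either way, compound 4 is expected to land close to compound 2, the expected step being a 1.3-fold higher number from compound 2 to compound 4 (0.11 log units; within the scatter). The estimate for compound 4 in this assay is 230 mg/kg, expected between 130 mg/kg and 400 mg/kg.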

Compound 4, dose for half-maximal effect: 100 mg/kg
The estimate for compound 4 lay 2.3-fold (0.36 log units) above the measured number; measured number below the stated range.
By their numbers in this assay, from the lowest: compounds 4, 2, 3 and 1 (each within the scatter of the next, the first and the last beyond it).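

Cyclopropyl in place of propargyl on an amide-type nitrogen can now be read directly in this assay: the swap gives a 1.8-fold lower number from compound 2 to compound 4 (0.26 log units; within the scatter) with the rest of the molecule held fixed, something compounds 1 and 3 could not show because they also differ on the aromatic ring. At this position, then, a group of three carbons holding a ring and one holding a triple bond cannot be told apart by this measurement, and a small real effect of the swap is neither shown nor ruled out. No measured information is available that would explain the result.

This single pair leaves open whether the same swap would read the same way with the methoxy group of compound 1 or the methyl group of compound 3 on the aromatic ring. It also leaves open whether a group of a different kind on this nitrogen, such as a longer alkyl chain, or a chain ending in an amine or a carboxylic acid, would move the number beyond the scatter.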